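Removing the methyl and shifting the fluorine in compound 3

The source may report more compounds than this note shows. Statements on the series, on what has been measured and on what is new or still open speak of the compounds shown alone.

Within the data shown here, compound 2 `C=CCn1c(=O)/c(=C\c2cc(F)ccc2C)[nH]c(=O)/c1=C\c1ccccc1OC` holds the lowest of the two numbers measured so far: in a functional assay on K562 cells (Homo sapiens) for cytotoxicity, read by CCK-8 assay, with a stated time of 72 h (a lower number here means a stronger inhibitor, a higher number a weaker inhibitor), compound 2 gives 1800 nM, while compound 1 `C=CCn1c(=O)/c(=C\c2cccc(F)c2)[nH]c(=O)/c1=C\c1ccccc1OC` gives 4100 nM. Among the measured compounds shown here, the one measured step that bears on the change, a 2.3-fold lower number from compound 1 to compound 2 (0.36 log units; beyond the scatter), came from a methyl in place of hydrogen on an aromatic carbon. Compound 3 `C=CCn1c(=O)/c(=C\c2ccccc2F)[nH]c(=O)/c1=C\c1ccccc1OC` makes the change (2-fluorophenyl in place of 5-fluoro-2-methylphenyl on a double-bonded chain carbon bound to an aromatic carbon), so that methyl is lost and the fluorine sits elsewhere. The step is expected to run upward, a 1.9-fold higher number from compound 2 to compound 3 (0.29 log units; within the scatter), so compound 3 is estimated at 3500 nM in this assay, within 1500 nM to 8000 nM.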

Compound 3, half-maximal inhibitory concentration: 5600 nM
Estimate against measurement, compound 3: 1.6-fold (0.20 log units) below; measured number inside the range.
By their numbers in this assay, from the lowest: compound 2; then compounds 1 and 3 (each within the scatter of the next).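

In this assay the change to 2-fluorophenyl gives a 3.1-fold higher number from compound 2 to compound 3 (0.49 log units; beyond the scatter) and leaves compound 2 with the lowest number of the three. Moving the fluorine with no methyl on the ring gives a 1.4-fold higher number from compound 1 to compound 3 (0.14 log units; within the scatter) and so does not separate 3-fluorophenyl from 2-fluorophenyl, which leaves 5-fluoro-2-methylphenyl as the only group here that stands apart. Nothing available explains this difference.

Still open, from the compounds shown here alone, is whether 2-methylphenyl, with no fluorine, would keep the lower number. Going by these compounds, whether an ethyl or a methoxy group could replace that methyl also remains unknown.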